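The compounds below may be only part of what the source reports. "The series", "measured", "known", "first", "only" and "open" are said of these compounds alone.

Measured in a functional assay on MGC-803 cells (Homo sapiens) for inhibition, read by MTT assay, with a stated time of 48 h; a lower number here means a stronger inhibitor, a higher number a weaker inhibitor:
- Compound 1 `COc1cc(NCc2ccccc2)cc(OC)c1OC`: > 80000 nM (a limit of the assay, not a number)
- Compound 2 `COc1ccc(CN(C(C)=O)c2cc(OC)c(OC)c(OC)c2)cc1O`: 79 nM
- Compound 3 `C/C=C/C(=O)N(Cc1ccc(OC)c(N)c1)c1cc(OC)c(OC)c(OC)c1`: 150 nM

Only two of these results are true numbers, and they lie within the scatter of each other. Compound 3, at 150 nM, therefore cannot be separated from compound 2, at 79 nM. Compound 1 stands apart as a limit, at > 80000 nM.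

The next compound is compound 4 `C/C=C/C(=O)N(Cc1ccc(OC)c(F)c1)c1cc(OC)c(OC)c(OC)c1`. It has fluoro in place of amino on an aromatic carbon, ortho to a methoxy group and meta to a large group, so 3-amino-4-methoxyphenyl becomes 3-fluoro-4-methoxyphenyl: fluoro in place of amino on an aromatic carbon.

Among the measured compounds shown here, no measured pair isolates this exchange, so the expectation is loose and is anchored on compound 3 at 150 nM. A moderate move in this assay toward a higher number, meaning a weaker inhibitor, is expected rather than a fall to a limit. The estimated step is a 2.7-fold higher number from compound 3 to compound 4 (0.43 log units; beyond the scatter), and it may not clear the scatter by much. The expected value for compound 4 is 400 nM, with an estimated range of 100 nM to 2000 nM.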

Compound 4, half-maximal inhibitory concentration: 1650 nM
Estimate against measurement, compound 4: 4.1-fold (0.62 log units) below, and the stated range covers the measured number.
By their numbers in this assay, from the lowest: compounds 2 and 3 (each within the scatter of the next); then compound 4. At a limit, above all of these: compound 1.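

In this assay, the 3-amino-4-methoxyphenyl group cannot be exchanged for 3-fluoro-4-methoxyphenyl without loss: fluoro in place of amino gives an 11-fold higher number from compound 3 to compound 4 (1.04 log units; beyond the scatter). Among the compounds shown here, this is the first pair that differs in one place, so it is the first direct reading of any single change, and it shows that this aromatic carbon, ortho to a methoxy group, is sensitive to the change of one heavy atom, with compound 4 still giving a true number rather than a limit. No measurement among the data bears on what lies behind the step.

A single exchange at this position cannot separate the loss of amino from the entry of fluoro, and that would take other groups at the same carbon, such as chloro, a methylamino group or a dimethylamino group. From the compounds shown here alone, whether a step of similar size would appear with a different chain on the amide carbonyl also stays open, since the reading rests on this one pair.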